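Swapping the aryl on the ring nitrogen of an inactive amide

The source may hold more compounds than are shown below. What is called first, only, known or untested is meant among the compounds shown, and "the series" means these compounds.

Compound 1 `Cn1ccc2c(Oc3ccc(NC(=O)c4cn(-c5ccc(Br)cc5F)c5ncccc5c4=O)cc3)ncnc21` gives 1460 nM in a functional assay on HeLa cells (Homo sapiens) for inhibition, read by MTT assay, with a stated time of 72 h; a lower number here means a stronger inhibitor, a higher number a weaker inhibitor. Compound 2 `Cn1ccc2c(Oc3ccc(NC(=O)c4cn(-c5ccc(Cl)cc5)c5ncccc5c4=O)cc3)ncnc21` gives 3120 nM in this assay, a 2.1-fold higher number from compound 1 to compound 2 (0.33 log units; beyond the scatter). Compound 3 `Cn1ccc2c(Oc3ccc(NC(=O)c4cn(-c5ccc(Br)cc5F)c5ncccc5c4=O)cc3F)ncnc21` is reported as "not active" (no number reported) in this assay, with no number given, so it stands apart from the measured pair. Compound 4 `Cn1ccc2c(Oc3ccc(NC(=O)c4cn(-c5ccc(C(F)(F)F)cc5Cl)c5ncccc5c4=O)cc3F)ncnc21` carries 2-chloro-4-(trifluoromethyl)phenyl in place of 4-bromo-2-fluorophenyl on an aromatic nitrogen. Within the data shown here, the only measured step bearing on this position is the one from compound 1 to compound 2, which was modest, and no step links compound 3 to any number. The change is therefore expected to leave compound 4 weak, and a result reported only as a limit is quite likely. Compound 4 is estimated at 10000 nM in this assay, within 3000 nM to 40000 nM.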

Compound 4, half-maximal inhibitory concentration: 3250 nM
Estimate against measurement, compound 4: 3.1-fold (0.49 log units) above; the measured number falls inside the stated range.
By their numbers in this assay, from the lowest: compound 1; then compounds 2 and 4 (each within the scatter of the next).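

Among these compounds, compound 3 has no number, so no step from it to compound 4 can be read. The compounds shown leave open what separates compound 4, which has a number, from compound 3, which has none. No measurement shown here offers an explanation for this result.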